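From fluoromethyl to methoxymethyl on a shared core

This account rests on a few compounds, and the source may have more. Where it says the series, first, only, none or still open, it means among the compounds named here.

Values in a functional assay on HL-60 cells (Homo sapiens) for cytotoxicity, read by WST assay, with a stated time of 48 h (on this read-out higher numbers stand for weaker inhibition and lower numbers for stronger inhibition), are as follows.
Compound 1 (`COc1cc(C(c2ccc(O)c(OC)c2)[C@@H](C)[C@@H](C)CO)ccc1O`): > 100000 nM is a limit of the assay, not a number
Compound 2 (`COc1cc(C(c2ccc(O)c(OC)c2)[C@@H](C)[C@@H](C)CF)ccc1O`): 38000 nM
Compound 3 (`COc1cc(C(c2ccc(O)c(OC)c2)[C@H](CF)C(C)C)ccc1O`): 19000 nM

Among the measured compounds shown here, compound 3 has no real separation from the only other true number. The gap between the two is a 2.0-fold lower number from compound 2 to compound 3 (0.30 log units; within the scatter) in size. The next compound, compound 4 (`COC[C@@H](C(C)C)C(c1ccc(O)c(OC)c1)c1ccc(O)c(OC)c1`), carries 1-(methoxymethyl)-2-methylpropyl in place of 1-(fluoromethyl)-2-methylpropyl (1-(methoxymethyl)-2-methylpropyl in place of 1-(fluoromethyl)-2-methylpropyl on a saturated chain carbon bound to two aromatic carbons) on the shared core. For the measured compounds named here, no measured compound has this group, so the guidance is indirect. The closest evidence comes from compound 1, whose chain carries oxygen rather than fluorine. Its comparisons are an at least 2.6-fold lower number from compound 1 to compound 2 (0.42 log units; beyond the scatter) and an at least 5.2-fold lower number from compound 1 to compound 3 (0.72 log units; beyond the scatter) in size, and both rest on its limit. On the strength of compound 1 and its step of an at least 5.2-fold lower number from compound 1 to compound 3 (0.72 log units; beyond the scatter), returning oxygen to the chain is expected to raise the number in this assay rather than lower it. The estimated move is a 2.1-fold higher number from compound 3 to compound 4 (0.32 log units; beyond the scatter) and small in size. Compound 4 is expected at about 40000 nM with an estimated range of 15000 nM to 100000 nM in this assay.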

Compound 4, half-maximal inhibitory concentration: 54000 nM
Beside the measured number, compound 4's estimate is 1.4-fold (0.13 log units) below it; the range from low to high includes it.
By their numbers in this assay, from the lowest: compounds 3, 2 and 4 (each within the scatter of the next, the first and the last beyond it). At a limit, above all of these: compound 1.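

In this assay, replacing 1-(fluoromethyl)-2-methylpropyl with 1-(methoxymethyl)-2-methylpropyl on a saturated chain carbon bound to two aromatic carbons gives a 2.8-fold higher number from compound 3 to compound 4 (0.45 log units; beyond the scatter), so this change weakens inhibition by a real margin, and here both ends of the step are true numbers. Against the isomeric fluorinated chain, the result is a 1.4-fold higher number from compound 2 to compound 4 (0.15 log units; within the scatter), so that pair cannot be told apart and the group that enters does not stand clear of every fluorinated chain. The remaining step, an at least 1.8-fold lower number from compound 1 to compound 4 (0.26 log units; that floor lies within the scatter), settles little, since it rests on a limit and not a number: the limit of > 100000 nM in this assay, at which 1 of the 4 values shown sits.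

As far as these compounds go, how a 1-(hydroxymethyl)-2-methylpropyl chain would read at this place remains open, and that would show whether the free alcohol and the methyl ether differ on this branched chain. An aminomethyl group or a longer ether such as ethoxymethyl is equally untested by the compounds shown.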